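The source may hold more compounds than are shown below. What is called first, only, known or untested is meant among the compounds shown, and "the series" means these compounds.

In an assay on HEK293 cells for positive allosteric modulation of metabotropic glutamate receptor 5 (Homo sapiens), read by FLIPR, with a stated time of 1 h (a lower number here means that less compound is needed, a higher number that more compound is needed for the effect), the three measured compounds gave the following numbers:

Compound 1 `CC1CC(C(=O)N2CCc3nc(C#Cc4ccccc4)sc3C2)C1`: 81 nM
Compound 2 `O=C(C1CCOCC1)N1CCc2nc(C#Cc3ccccc3)sc2C1`: 290 nM
Compound 3 `O=C(C1CCCCO1)N1CCc2nc(C#Cc3ccccc3)sc2C1`: 320 nM

Compound 3 carries the highest number of the three. Its nearest neighbour is compound 2, with a 1.1-fold higher number from compound 2 to compound 3 (0.04 log units; within the scatter), a gap that stays within the scatter. The furthest is compound 1, with a 4.0-fold higher number from compound 1 to compound 3 (0.60 log units; beyond the scatter), and the related step of a 3.6-fold higher number from compound 1 to compound 2 (0.55 log units; beyond the scatter) is of much the same size. Both oxygen-containing ring groups on the carbonyl carbon therefore sit close together, set apart from the 3-methylcyclobutyl group of compound 1.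

Compound 4 `O=C(CC1CCOCC1)N1CCc2nc(C#Cc3ccccc3)sc2C1` is the next compound. The change is (oxan-4-yl)methyl in place of oxan-2-yl on a carbonyl carbon. Among the compounds with values here, the only step that bears on it directly is the one from compound 2 to compound 3, which moved the ring oxygen without a change beyond the scatter. Within the data shown here, no measured pair shows what the added methylene between ring and carbonyl does, so a step beyond the scatter in either direction cannot be ruled out. The expected step for compound 4 is a 1.1-fold higher number from compound 3 to compound 4 (0.04 log units; within the scatter), none beyond the scatter. Compound 4 is estimated at 350 nM, within 120 nM to 1000 nM.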

Compound 4, half-maximal effective concentration: 470 nM
Compound 4: the middle estimate sits 1.3-fold (0.13 log units) below what was measured, within the range that was stated.
By their numbers in this assay, from the lowest: compound 1; then compounds 2, 3 and 4 (each within the scatter of the next).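

In this assay, within the data shown here, setting the ring one methylene away from the carbonyl carbon gives a 1.5-fold higher number from compound 3 to compound 4 (0.17 log units; within the scatter) and a 1.6-fold higher number from compound 2 to compound 4 (0.21 log units; within the scatter), so the (oxan-4-yl)methyl group stays level with both directly attached oxane rings, a change of linkage that the earlier compounds did not cover. The gap to the 3-methylcyclobutyl group also persists with this new group, at a 5.8-fold higher number from compound 1 to compound 4 (0.76 log units; beyond the scatter), so all three oxygen-containing groups now stand apart from compound 1. No measurement at hand accounts for these steps.

The compounds shown leave open whether the ring oxygen or the ring itself sets compound 1 apart, a question that a cyclohexyl group on the carbonyl carbon would bear on. Also open, as far as these compounds go, is how this position responds to a longer chain such as 2-(oxan-4-yl)ethyl, or to an amine such as piperidin-4-yl.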